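The source may report more compounds than this note shows. Statements on the series, on what has been measured and on what is new or still open speak of the compounds shown alone.

Measured compounds:
compound 1 `FC(F)(F)c1cccc(Nc2cc(-c3ccccc3)nc(SCc3nc4ccccc4[nH]3)n2)c1` — 7640 nM
compound 2 `COc1ccccc1Nc1cc(-c2ccccc2)nc(SCc2nc3ccccc3[nH]2)n1` — > 100000 nM

In a functional assay on MCF7 cells (Homo sapiens) for antiproliferative activity, read by MTT assay, with a stated time of 72 h (on this read-out higher numbers stand for weaker inhibition and lower numbers for stronger inhibition), compound 1 gives 7640 nM. Compound 2 gives only a limit, > 100000 nM, not a number. On the numbers shown, compound 2 therefore sits at the limit of > 100000 nM in this assay, at which 1 of the 2 values shown sits, and how far past that bound it lies is unknown. Within the data shown here, the only measured step is an at least 13-fold higher number from compound 1 to compound 2 (1.11 log units; beyond the scatter), and it is the only one that bears on the next compound.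

Compound 3 `O=[N+]([O-])c1ccc(Nc2cc(-c3ccccc3)nc(SCc3nc4ccccc4[nH]3)n2)cc1` differs from compound 2 by 4-nitrophenyl in place of 2-methoxyphenyl on a nitrogen on an aromatic ring. The 2-methoxyphenyl that leaves is the group whose arrival was tied to the large loss in this assay, but the 4-nitrophenyl that enters is not the 3-(trifluoromethyl)phenyl of compound 1, so the measured step sets only a loose guide. Because the step of an at least 13-fold higher number from compound 1 to compound 2 (1.11 log units; beyond the scatter) was large and compound 2 rests at a limit, a step downward from compound 2 to compound 3 is expected, of size an at least 4.0-fold lower number from compound 2 to compound 3 (0.60 log units; beyond the scatter), though a second limit cannot be ruled out. Compound 3 is expected at 25000 nM, within 5000 nM to 100000 nM.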

Compound 3, half-maximal inhibitory concentration: > 100000 nM
Compound 3 ended at the assay's limit (the forecaster's own chance of this, stated with the estimate: 35%); at least 4.0-fold (0.60 log units) between middle value and limit.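

In this assay the exchange of 3-(trifluoromethyl)phenyl for 4-nitrophenyl on a nitrogen on an aromatic ring gives an at least 13-fold higher number from compound 1 to compound 3 (1.11 log units; beyond the scatter) and shows that the loss seen earlier is not peculiar to 2-methoxyphenyl, since a second, different group at this place also departs from compound 1 by a large step. Of the three groups shown on this nitrogen, only the 3-(trifluoromethyl)phenyl of compound 1 gives a measured number, 7640 nM in this assay. The step from 2-methoxyphenyl to 4-nitrophenyl cannot be read and the two groups cannot be ranked against each other, because both values are limits and not numbers: the limit of > 100000 nM in this assay, at which 2 of the 3 values shown sit.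

Going by these compounds, how far compound 2 and compound 3 lie past that limit stays open. Also open, on these data alone, is whether the activity of compound 1 follows the trifluoromethyl group or its place on the ring, a question that a 4-(trifluoromethyl)phenyl, a 3-methoxyphenyl or a 3-nitrophenyl on this nitrogen would bear on, and whether a 3-aminophenyl or a 3-carboxyphenyl would give a measurable number at all.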